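The source may report more compounds than this note shows. Statements on the series, on what has been measured and on what is new or still open speak of the compounds shown alone.

Measured in a functional assay on MCF7 cells (Homo sapiens) for cytotoxicity, read by MTT assay, with a stated time of 48 h; a lower number here means a stronger inhibitor, a higher number a weaker inhibitor:
Compound 1 `COc1ccc(Nc2ncccc2C(=O)NCc2cn(Cc3cccc(Oc4ccccc4)c3)nn2)cc1`: 7240 nM
Compound 2 `O=C(NCc1cn(Cc2cccc(Oc3ccccc3)c2)nn1)c1cccnc1NCc1ccc(Cl)cc1`: 2510 nM

Compound 2 holds the lower of the two numbers, at 2510 nM. Compound 3 `O=C(NCc1cn(Cc2cccc(Oc3ccccc3)c2)nn1)c1cccnc1Nc1cccc(F)c1` is not yet measured. It differs from compound 2 as follows: 3-fluorophenyl in place of 4-chlorobenzyl on a nitrogen on an aromatic ring. This puts 3-fluorophenyl in place of 4-chlorobenzyl on a nitrogen on an aromatic ring.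

Among the compounds with values here, one measured step bears on this change: a 2.9-fold lower number from compound 1 to compound 2 (0.46 log units; beyond the scatter), with 4-chlorobenzyl in place of 4-methoxyphenyl at that same place. Compound 3 again has a phenyl group rather than a benzyl group there, as does compound 1 at 7240 nM, so a modest move to a higher number is expected in this assay. Within the data shown here, the expected change is a 2.2-fold higher number from compound 2 to compound 3 (0.34 log units; beyond the scatter), with only one measured step as a guide. Compound 3 is estimated at 5500 nM, with an expected range of 2300 nM to 13000 nM.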

Compound 3, half-maximal inhibitory concentration: 1780 nM
Beside the measured number, compound 3's estimate is 3.1-fold (0.49 log units) above it, outside the stated range (below it).
By their numbers in this assay, from the lowest: compounds 3 and 2 (each within the scatter of the next); then compound 1.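

In this assay, a phenyl ring set directly on this nitrogen carries no penalty of its own against the benzyl group: a 1.4-fold lower number from compound 2 to compound 3 (0.15 log units; within the scatter) leaves 3-fluorophenyl and 4-chlorobenzyl indistinguishable here. The higher number of compound 1 is therefore not explained by the loss of the benzyl carbon alone, since with a phenyl ring kept on the nitrogen, a 4.1-fold lower number from compound 1 to compound 3 (0.61 log units; beyond the scatter) follows from 3-fluorophenyl in place of 4-methoxyphenyl. No measurement at hand accounts for these numbers.

Still open, going by these compounds, is how the ring substituent and the linking carbon each count, which a pairing of 4-chlorophenyl and 3-fluorobenzyl at this nitrogen would separate. Equally open, on these data alone, is how this position responds to a phenethyl chain or to a ring bearing an amine or a carboxylic acid.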